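The compounds below may be only part of what the source reports. "The series", "measured", "known", "first", "only" and "open" are said of these compounds alone.

Measured so far in a functional assay on the whole organism with Rattus norvegicus as the target; a higher number here means that more compound is needed for the effect, a lower number that less compound is needed:
Compound 1 `CCOC(=O)C(=O)Nc1cccc(OC)c1C#N` gives 5.3 mg/kg
Compound 2 `CCNc1cccc(NC(=O)C(=O)OCC)c1C#N` gives 0.03 mg/kg
Compound 3 `CCOC(=O)C(=O)Nc1cccc(N2CCCCC2)c1C#N` gives 2.2 mg/kg

Compound 3 holds the middle place of these three numbers, with compound 2 far lower and compound 1 only modestly higher. Compound 4 `CCOC(=O)C(=O)Nc1cccc([N+](=O)[O-])c1C#N` is not yet measured and differs from compound 3 as follows: nitro in place of piperidin-1-yl on an aromatic carbon. Changes at this place have varied widely. Going to piperidin-1-yl from methoxy gave a 2.4-fold lower number from compound 1 to compound 3 (0.38 log units; beyond the scatter) only, while ethylamino stands apart with a 180-fold lower number from compound 1 to compound 2 (2.25 log units; beyond the scatter) and a 73-fold higher number from compound 2 to compound 3 (1.87 log units; beyond the scatter). For the measured compounds named here, no measured compound carries nitro, so the modest step is the safer guide. The expected change is a 1.5-fold lower number from compound 3 to compound 4 (0.17 log units; within the scatter) and no step beyond the scatter is expected. For compound 4 the estimate is 1.5 mg/kg with an expected range from 0.2 mg/kg to 8 mg/kg.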

Compound 4, dose for half-maximal effect: 0.4 mg/kg
Estimate against measurement, compound 4: 3.8-fold (0.57 log units) above, and the stated range covers the measured number.
By their numbers in this assay, from the lowest: compound 2; then compound 4; then compound 3; then compound 1.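

In this assay, for the compounds shown here, nitro brings a clear drop at this place, ortho to a cyano group, with a 5.5-fold lower number from compound 3 to compound 4 (0.74 log units; beyond the scatter) and a 13-fold lower number from compound 1 to compound 4 (1.12 log units; beyond the scatter) so that ethylamino is no longer the only group here that lowers the number strongly. Even so, nitro does not reach ethylamino, with a 13-fold higher number from compound 2 to compound 4 (1.12 log units; beyond the scatter) as the remaining gap. The order at this place now runs ethylamino, nitro, piperidin-1-yl, methoxy.

On these data alone, whether a plain amine or a methylamino group would come closer to ethylamino stays open, as does the effect of a longer chain on that nitrogen. Nothing measured here gives a reason for this order.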